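The source may report more compounds than this note shows. Statements on the series, on what has been measured and on what is new or still open speak of the compounds shown alone.

Compound 1 `FC(F)(F)c1ccc(-c2ccc3c(NCCCNCc4ccco4)ccnc3c2)cc1` was tested in an ADME assay on HepG2 cells (Homo sapiens) for cytotoxicity, read by luminescence, CellTiter-Glo and ATP content, with a stated time of 72 h (on this read-out higher numbers stand for an effect only at larger amounts of compound and lower numbers for an effect already at smaller amounts), and gave 3470 nM. Its only companion so far, compound 2 `FC(F)(F)c1cc(-c2ccc3c(NCCCNCc4ccco4)ccnc3c2)cc(C(F)(F)F)c1`, gives 2410 nM in this assay, a number within the scatter of compound 1, so the two cannot be told apart. Compound 3 `c1ccc(Cc2ccc3c(NCCCNCc4ccco4)ccnc3c2)cc1` has not yet been tested; it differs from compound 1 by benzyl in place of 4-(trifluoromethyl)phenyl on an aromatic carbon. Within the data shown here, no measured pair shows this change, so its size is unknown; a modest move toward an effect only at larger amounts is expected, a 1.4-fold higher number from compound 1 to compound 3 (0.16 log units; within the scatter), though a step within the scatter would not surprise. Compound 3 is expected to give 5000 nM in this assay, between 2000 nM and 14000 nM.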

Compound 3, half-maximal effective concentration: 16000 nM
The estimate for compound 3 lay 3.2-fold (0.51 log units) below the measured number; measured number outside the range, above it.
By their numbers in this assay, from the lowest: compounds 2 and 1 (each within the scatter of the next); then compound 3.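

Benzyl in place of 4-(trifluoromethyl)phenyl on this aromatic carbon gives a 4.6-fold higher number from compound 1 to compound 3 (0.66 log units; beyond the scatter) in this assay. Among these compounds, this is the first sign that the position responds to what it carries, as compound 1 and compound 2 stand within the scatter of each other. Nothing at hand accounts for the step.

Going by these compounds, whether the step follows the loss of trifluoromethyl or the methylene of benzyl remains open, and a plain phenyl here would separate the two. Also open, on these data alone, is how an amine, a carboxylic acid or a longer chain at this position would read.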